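A difluoromethoxy group on the outer ring of compound 2

The source may report more compounds than this note shows. Statements on the series, on what has been measured and on what is new or still open speak of the compounds shown alone.

Compound 2 `Cc1oc(C(=O)NS(=O)(=O)c2ccccc2)cc1COc1ccc(-c2ccccc2)cc1` was tested in an assay on cells for displacement of a labelled ligand from prostaglandin E2 receptor EP4 subtype (Homo sapiens), read by scintillation counting (on this read-out lower numbers stand for stronger inhibition and higher numbers for weaker inhibition), and gives 25 nM. Among the two plain numbers shown, compound 2 stands at the upper end, but compound 3 `COc1ccc(-c2ccc(OCc3cc(C(=O)NS(=O)(=O)c4c(C)noc4C)oc3C)cc2)c(C)c1` gives 24 nM in this assay, a value within the scatter of compound 2, so the two cannot be told apart. Compound 1 `Cc1oc(C(=O)O)cc1COc1ccc(-c2nnco2)cc1` gives only a limit in this assay, > 10000 nM (the limit of > 10000 nM in this assay, at which 1 of the 3 values shown sits). Compound 4 `Cc1oc(C(=O)NS(=O)(=O)c2ccccc2)cc1COc1ccc(-c2ccc(OC(F)F)cc2)cc1` has not been measured; it differs from compound 2 in one place: difluoromethoxy in place of hydrogen on an aromatic carbon. Among the compounds with values here, no step between measured compounds is available, yet the substituted outer ring of compound 3 sits at 24 nM in this assay. For compound 4 the step is expected to stay within the scatter, a 1.3-fold lower number from compound 2 to compound 4 (0.10 log units; within the scatter). Compound 4 is estimated at 20 nM, between 7 nM and 60 nM.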

Compound 4, inhibition constant: 1.3 nM
Beside the measured number, compound 4's estimate is 15-fold (1.19 log units) above it; measured number below the stated range.
By their numbers in this assay, from the lowest: compound 4; then compounds 3 and 2 (each within the scatter of the next). At a limit, above all of these: compound 1.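

Difluoromethoxy in place of hydrogen on the outer ring, para to a large group, gives a 19-fold lower number from compound 2 to compound 4 (1.28 log units; beyond the scatter) in this assay, so this position responds strongly to substitution. Compound 3 also carries a substituted outer ring, but it differs from compound 2 in more than one place, so it could not show this.

From the compounds shown here alone, whether trifluoromethoxy, a single fluorine or an amine at this place would do the same remains open. Nothing among the data shown explains the gain.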